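Swapping benzyloxy for cyclopentylamino at the limit of tolerance

The source may hold more compounds than are shown below. What is called first, only, known or untested is meant among the compounds shown, and "the series" means these compounds.

Values from an ADME assay on Akata cells (Homo sapiens) for cytotoxicity, with a stated time of 7 days (a higher number here means that more compound is tolerated, a lower number that less compound is tolerated), follow

Compound 1 (`COCCOc1nc(N)nc2c1ncn2/C=C1/CC1(CO)CO`) gives > 20000 nM
Compound 2 (`Nc1nc(OCc2ccccc2)c2ncn(/C=C3/CC3(CO)CO)c2n1`) gives > 20000 nM
Compound 3 (`Nc1nc2c(ncn2/C=C2/CC2(CO)CO)c(=O)[nH]1`) gives > 20000 nM

Compound 2 stands at > 20000 nM as a limit of the test and not as a number. It has company there, with the limit of > 20000 nM in this assay, at which 3 of the 3 values shown sit, and no exact reading among them.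

Compound 4 (`Nc1nc(NC2CCCC2)c2ncn(/C=C3/CC3(CO)CO)c2n1`) has not yet been measured. It carries cyclopentylamino in place of benzyloxy on an aromatic carbon and otherwise matches compound 2.

The closest measured change is a step that the two limits leave unreadable from compound 1 to compound 2 and it gives no usable size, since both of its ends are limits. The data therefore offer no direct guide to the size of this swap, though none of the three measured compounds has yet given a number under the limit. The expectation in this assay is no step beyond the usual scatter, and compound 4 may well report only a limit again. Compound 2 at > 20000 nM anchors that expectation, and this value is a limit. The expected size of the change is a number no higher from compound 2 to compound 4 (the limit leaves the size open) as an estimate. For compound 4 the estimated value is 20000 nM within an expected range of 8000 nM to 30000 nM.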

Compound 4, half-maximal cytotoxic concentration: > 20000 nM
Compound 4 ended at the assay's limit (the forecaster's own chance of this, stated with the estimate: 70%); the middle value lies on the limit itself.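

The steps to compound 4 from compound 1 and from compound 2 cannot be read, since all three compounds report only a limit: the limit of > 20000 nM in this assay, at which 4 of the 4 values shown sit.

What the compounds shown leave open is what concentration of any of them would reach the half-maximal cytotoxic point in this assay, and whether cyclopentylamino and benzyloxy differ there.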